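This account rests on a few compounds, and the source may have more. Where it says the series, first, only, none or still open, it means among the compounds named here.

Measured so far:
compound 1, `Nc1cc(C(F)(F)F)c(Br)nc1C(=O)NCCC(F)(F)F`, gives 49 ug/mL
compound 2, `CC(O)CNC(=O)c1nc(Br)c(C(F)(F)F)cc1N`, gives 120 ug/mL

In a physicochemical assay for solubility, at pH 6.8 (on this read-out higher numbers stand for higher solubility and lower numbers for lower solubility), compound 2 stands highest of the two numbers; the nearest is compound 1, and the step of a 2.4-fold higher number from compound 1 to compound 2 (0.39 log units; beyond the scatter) lies beyond the scatter. Compound 3, `CC(C)(O)CNC(=O)c1nc(Br)c(C(F)(F)F)cc1N`, is not yet measured. Its change from compound 2: methyl in place of hydrogen on a saturated chain carbon bound to an oxygen on a saturated carbon and two saturated chain carbons. Going by the values given here, the only measured step, a 2.4-fold higher number from compound 1 to compound 2 (0.39 log units; beyond the scatter), puts 1-hydroxyethyl in place of 2,2,2-trifluoroethyl and so is a different kind of change; no measured pair tests methyl in place of hydrogen on a carbon bearing a hydroxyl. Among the compounds with values here, with no comparable step, the expectation for compound 3 in this assay is a change that does not go beyond the scatter, a 1.3-fold lower number from compound 2 to compound 3 (0.10 log units; within the scatter), with a slight lean downward. Compound 3 is therefore estimated at 95 ug/mL in this assay, with a range from 45 ug/mL to 200 ug/mL.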

Compound 3, solubility: 28 ug/mL
Beside the measured number, compound 3's estimate is 3.4-fold (0.53 log units) above it, outside the stated range (below it).
By their numbers in this assay, from the lowest: compounds 3 and 1 (each within the scatter of the next); then compound 2.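

In this assay, going by these compounds alone, methyl in place of hydrogen on a saturated chain carbon bound to an oxygen on a saturated carbon and two saturated chain carbons gives a 4.3-fold lower number from compound 2 to compound 3 (0.63 log units; beyond the scatter), so this position responds to the addition of one methyl, which the earlier compounds could not show. Going from 2-hydroxypropyl to 2-hydroxy-2-methylpropyl also removes the separation from compound 1 seen with compound 2: a 1.8-fold lower number from compound 1 to compound 3 (0.24 log units; within the scatter), and that step stays within the scatter. Nothing measured here accounts for this result.

Still open, as far as these compounds go, is how an ether in place of the hydroxyl, an amine on the same chain, or a longer chain would read in this assay. The compounds shown also leave open whether the methyl step would hold on a different core.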